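Aryl to cyclohexyl swap on the amine of compound 3

The compounds below may be only part of what the source reports. "The series", "measured", "known", "first", "only" and "open" are said of these compounds alone.

Compound 3 `Cc1ccc(NC2=CC(=O)c3c(nc4n3[C@H]3OC[C@@H](O)[C@H]3OC4)C2=O)cc1` gives 1550 nM in a functional assay on MGC-803 cells (Homo sapiens) for inhibition, read by sulforhodamine B assay; on this read-out higher numbers stand for weaker inhibition and lower numbers for stronger inhibition. Compound 1 `COc1ccc(NC2=CC(=O)c3c(nc4n3[C@H]3OC[C@@H](O)[C@H]3OC4)C2=O)cc1` gives 2150 nM and compound 2 `CCOc1ccc(NC2=CC(=O)c3c(nc4n3[C@H]3OC[C@@H](O)[C@H]3OC4)C2=O)cc1` gives 2090 nM; the steps of a 1.4-fold lower number from compound 1 to compound 3 (0.14 log units; within the scatter) and a 1.3-fold lower number from compound 2 to compound 3 (0.13 log units; within the scatter) both fall within the scatter, as does a 1.0-fold lower number from compound 1 to compound 2 (0.01 log units; within the scatter), so the three values sit together with no ordering that can be trusted. Compound 4 `O=C1C(NC2CCCCC2)=CC(=O)c2c1nc1n2[C@H]2OC[C@@H](O)[C@H]2OC1` carries cyclohexyl in place of 4-methylphenyl on an amine nitrogen. For the measured compounds named here, none of the measured steps touches the ring on the amine nitrogen; each only varies the group on the aromatic ring, and all stay within the scatter. Going by the values given here, no measured step therefore bears on this change, and its direction is not known from the data. Compound 4 is expected to give 3000 nM (range 900 nM to 10000 nM), an estimated step of a 1.9-fold higher number from compound 3 to compound 4 (0.29 log units; within the scatter) with wide uncertainty.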

Compound 4, half-maximal inhibitory concentration: > 8000 nM
Compound 4: a limit, no number (the forecaster's own chance of this, stated with the estimate: 10%); middle value at least 2.6-fold (0.42 log units) away from the limit.
By their numbers in this assay, from the lowest: compounds 3, 2 and 1 (each within the scatter of the next). At a limit, above all of these: compound 4.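

Cyclohexyl in place of the aryl groups on an amine nitrogen moves the read-out beyond the scatter, which the changes on the aromatic ring did not do: an at least 5.1-fold higher number from compound 3 to compound 4 (0.71 log units; beyond the scatter), an at least 3.8-fold higher number from compound 2 to compound 4 (0.58 log units; beyond the scatter) and an at least 3.7-fold higher number from compound 1 to compound 4 (0.57 log units; beyond the scatter). An aromatic ring on this amine nitrogen therefore goes with stronger inhibition than cyclohexyl in this series. Compound 4 is read only as a limit: the limit of > 8000 nM in this assay, at which 1 of the 4 values shown sits.

From the compounds shown here alone, the full size of these steps stays open. Also open, going by these compounds, is how a pyridyl ring or a benzyl group on the amine nitrogen would read in this assay.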